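A few compounds are considered here, and "the series" means these few. Any claim that something is new, unique, unknown or untested is made for them only; others in the source may bear on it.

In a functional assay on QGY7701 cells (Homo sapiens) for cytotoxicity, read by MTT assay, with a stated time of 24 h (on this read-out lower numbers stand for stronger inhibition and higher numbers for weaker inhibition), compound 1 `C=CC1=C(C(=O)O)C(c2ccc(F)cc2)OC1` gives only a limit, > 100000 nM. Compound 2 `C=CC1=C(C(=O)Nc2ccc(C)cc2)C(c2ccc(F)cc2)OC1` gives 59200 nM. Compound 3 `C=CC1=C(C(=O)NCCCCC)C(c2ccc(F)cc2)OC1` likewise returns only a limit, > 100000 nM. Compound 3 therefore sits at the limit of > 100000 nM in this assay, at which 2 of the 3 values shown sit, so its place among the numbers shown is not readable beyond that. Compound 4 `C=CC1=C(C(=O)NCc2ccccc2)C(c2ccc(F)cc2)OC1` differs from compound 3 by phenyl in place of butyl on a saturated chain carbon bound to an amide-type nitrogen. Among the compounds with values here, no measured step covers this change directly; the nearest are an at least 1.6-fold higher number from compound 2 to compound 3 (0.22 log units; that floor lies within the scatter), which exchanged an aromatic group for a chain, and an at least 1.6-fold lower number from compound 1 to compound 2 (0.22 log units; that floor lies within the scatter), both too small to read against the scatter. Since compound 4 carries phenyl again, the expectation for compound 4 is 80000 nM, between 30000 nM and 200000 nM. That expectation means a step of an at least 1.2-fold lower number from compound 3 to compound 4 (0.09 log units; that floor lies within the scatter).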

Compound 4, half-maximal inhibitory concentration: 67600 nM
Compound 4: the middle estimate sits 1.2-fold (0.07 log units) above what was measured; the range from low to high includes it.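

In this assay, benzyl on the amide-type nitrogen gives a measured number, as 4-methylphenyl does, and the two do not separate: a 1.1-fold higher number from compound 2 to compound 4 (0.06 log units; within the scatter). Phenyl in place of butyl on the saturated chain carbon shows no gain beyond the scatter, since both floors stay within it: an at least 1.4-fold lower number from compound 3 to compound 4 (0.17 log units; that floor lies within the scatter) and an at least 1.4-fold lower number from compound 1 to compound 4 (0.17 log units; that floor lies within the scatter). Compound 1 and compound 3 remain limits of the assay, not numbers: the limit of > 100000 nM in this assay, at which 2 of the 4 values shown sit.

From the compounds shown here alone, whether a longer chain carrying the phenyl, or an amine or a carboxylic acid on that phenyl, would move the number beyond the scatter stays open.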